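The compounds below may be only part of what the source reports. "The series", "measured", "known", "first", "only" and "open" are said of these compounds alone.

Of the compounds shown here, three sharing one core have been measured in a physicochemical assay for lipophilicity; a lower number here means a more polar compound, a higher number a more lipophilic compound: compound 1 `CN1CCN(c2cc(C(F)(F)F)ccc2[C@H]2CCOc3cc(S(=O)(=O)Nc4nccs4)ccc32)CC1` gives 2.1, compound 2 `Cn1nccc1-c1cc(C(F)(F)F)ccc1[C@H]1CCOc2cc(S(=O)(=O)Nc3nccs3)ccc21` gives 2.2, and compound 3 `O=S(=O)(Nc1nccs1)c1ccc2c(c1)OCC[C@@H]2c1ccc(C(F)(F)F)cc1-c1ccc(F)cn1` gives 3.5. Compound 3 thus holds the highest number of the three, clearly apart from the other two.

Compound 4 `O=S(=O)(Nc1nccs1)c1ccc2c(c1)OCC[C@@H]2c1ccc(C(F)(F)F)cc1-n1ccnn1` has not yet been measured. It differs from compound 3 at a single place: 1H-1,2,3-triazol-1-yl in place of 5-fluoropyridin-2-yl on an aromatic carbon. In words, 1H-1,2,3-triazol-1-yl stands in place of 5-fluoropyridin-2-yl on an aromatic carbon, ortho to a large group and meta to a trifluoromethyl group.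

All three measured steps concern this same place. Bringing in 5-fluoropyridin-2-yl gave a number 1.40 log units higher from compound 1 to compound 3 (beyond the scatter) and also a number 1.30 log units higher from compound 2 to compound 3 (beyond the scatter), while exchanging the other two groups gave only a number 0.10 log units higher from compound 1 to compound 2 (within the scatter). For the measured compounds named here, no measured compound carries a triazole, so any comparison is an analogy. Here the incoming group is taken to behave more like the 1-methyl-1H-pyrazol-5-yl of compound 2, at 2.2, than like the group it replaces. The fall expected in this assay is therefore nearly as large as the step into compound 3, though less certain. The estimated change is a number 1.10 log units lower from compound 3 to compound 4 (beyond the scatter). For compound 4 the expected value is 2.4, with an estimated range of 1.9 to 2.9.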

Compound 4, distribution coefficient: 2.3
Compound 4: the middle estimate sits 0.10 log units above what was measured, within the range that was stated.
By their numbers in this assay, from the lowest: compounds 1, 2 and 4 (each within the scatter of the next); then compound 3.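

In this assay the move to 1H-1,2,3-triazol-1-yl produces a large step (a number 1.20 log units lower from compound 3 to compound 4 (beyond the scatter)), so a third group at this place, ortho to a large group and meta to a trifluoromethyl group, now lies far from 5-fluoropyridin-2-yl. Set against the other two groups, the triazole gives only small steps (a number 0.10 log units higher from compound 2 to compound 4 (within the scatter) and a number 0.20 log units higher from compound 1 to compound 4 (within the scatter)), which places three rather different groups within the scatter of one another and leaves compound 3 as the only one standing apart among the four. No measurement here accounts for this separation, so the numbers describe it without explaining it.

The group in compound 3 differs from the other three in several ways at once, including its six-membered aromatic ring and its fluorine, so the compounds shown cannot tell which of these features goes with the higher number; a pyridin-2-yl without the fluorine, or a plain phenyl ring, would help to separate them. Also open, on these data alone, is where a small methyl group or a simple amine at this place would fall.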